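Carrying a Small Swap Onto a Weaker Core

The compounds below may be only part of what the source reports. "The series", "measured", "known", "first", "only" and "open" are said of these compounds alone.

Compound 2 `O=c1ccn([C@@H]2O[C@H](COP(=O)(O)OP(=O)(O)O)[C@@H](O)[C@H]2O)c(SCc2ccccc2)n1` and compound 1 `COc1nc(=O)ccn1[C@@H]1O[C@H](COP(=O)(O)OP(=O)(O)O)[C@@H](O)[C@H]1O` share one core and differ in a single place: methoxy in place of benzylsulfanyl on an aromatic carbon. In an in vitro functional assay on 1321-N1 cells for agonist activity at P2Y purinoceptor 4 (Homo sapiens), read by scintillation proximity assay and inositol phosphate accumulation (on this read-out lower numbers stand for an effect already at smaller amounts and higher numbers for an effect only at larger amounts of compound), compound 2 gives 5980 nM, and in this assay compound 1 gives 4490 nM. The step of a 1.3-fold lower number from compound 2 to compound 1 (0.12 log units; within the scatter), so the two values show no real difference.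

Compound 3 `O=c1ccn([C@@H]2O[C@H](COP(=O)(O)O)[C@@H](O)[C@H]2O)c(SCc2ccccc2)n1` keeps the benzylsulfanyl group of compound 2 but has a different core: a hydrogen atom in place of a group of 4 heavy atoms (3 oxygen, 1 phosphorus; no ring), on an oxygen. In this assay compound 3 gives only a limit of the assay, > 100000 nM. The step of an at least 16-fold higher number from compound 2 to compound 3 (1.22 log units; beyond the scatter), and this sits at the limit of > 100000 nM in this assay, at which 1 of the 3 values shown sits.

Compound 4 `COc1nc(=O)ccn1[C@@H]1O[C@H](COP(=O)(O)O)[C@@H](O)[C@H]1O` has not been measured in this assay. It arises from compound 3 by methoxy in place of benzylsulfanyl on an aromatic carbon, which is the same change that turns compound 2 into compound 1, at the same place. For compound 4 the step is expected to be a step that the limit leaves unreadable from compound 3 to compound 4, because the earlier step of a 1.3-fold lower number from compound 2 to compound 1 (0.12 log units; within the scatter). Compound 4 is therefore estimated at about 150000 nM, expected between 50000 nM and 500000 nM, most likely again reported as a limit rather than a number.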

Compound 4, half-maximal effective concentration: > 100000 nM
Compound 4 was reported as a limit; the forecaster's own chance of this, stated with the estimate: 85%; the middle value lies beyond the limit too.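

In this assay compound 4 gives > 100000 nM, which is a limit of the assay, and with compound 3 also at a limit, the step between these two compounds cannot be read. The swap of methoxy for benzylsulfanyl therefore cannot be compared across the two cores, but the loss of the group of 4 heavy atoms on the oxygen can be read on the methoxy side, with an at least 22-fold higher number from compound 1 to compound 4 (1.34 log units; beyond the scatter), and it points the same way as on the benzylsulfanyl side: the same change on two cores in this assay, an at least 16-fold higher number (1.22 log units; beyond the scatter) from compound 2 to compound 3 and an at least 22-fold higher number (1.34 log units; beyond the scatter) from compound 1 to compound 4; the limit leaves it open whether they differ. The series thus shows that both compounds with the shorter phosphate group lie far from their partners, but it does not show whether the swap, which made no real difference on the core of compound 2, also makes none on the core of compound 3: the limit of > 100000 nM in this assay, at which 2 of the 4 values shown sit.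

The compounds shown leave open how an amine or a longer chain in place of benzylsulfanyl would read on the core of compound 1. They also leave open what a triphosphate on that same oxygen would do.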